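Fluoro to methyl on the phenyl ring of compound 2

This account rests on a few compounds, and the source may have more. Where it says the series, first, only, none or still open, it means among the compounds named here.

Compound 1, `CCc1cc2ccccc2nc1-c1cc(-c2ccccc2)no1`: in a functional assay on PC-3 cells (Homo sapiens) for inhibition, read by MTT assay, with a stated time of 24 h (a higher number here means a weaker inhibitor, a lower number a stronger inhibitor), compound 1 gives > 100000 nM, which is a limit of the assay.
Compound 2, `CCc1cc2ccccc2nc1-c1cc(-c2ccc(F)cc2)no1`: in this assay compound 2 gives > 100000 nM, again a limit of the assay.
Compound 3, `CCCCc1cc2ccccc2nc1-c1cc(-c2ccc(F)cc2)no1`: in this assay compound 3 gives 26300 nM.

Compound 2 therefore stands at the limit of > 100000 nM in this assay, at which 2 of the 3 values shown sit, and only compound 3 provides a number. The step that the two limits leave unreadable from compound 1 to compound 2 cannot be sized, since both ends are limits. For the measured compounds named here, the step of an at least 3.8-fold lower number from compound 2 to compound 3 (0.58 log units; beyond the scatter) is the one readable change, and it concerns the chain, not the phenyl ring.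

Compound 4, `CCc1cc2ccccc2nc1-c1cc(-c2ccc(C)cc2)no1`, differs from compound 2 by methyl in place of fluoro on an aromatic carbon. Going by the values given here, no measured step touches this exchange: the earlier change at the same ring, from compound 1 to compound 2, left both values at the limit, and the chain change from compound 2 to compound 3 concerns another part of the molecule. The number for compound 4 is thus expected to remain near the limit, with a step of a number no higher from compound 2 to compound 4 (the limit leaves the size open) from compound 2. Compound 4 is estimated at 100000 nM, in a range from 30000 nM to 300000 nM, with a real chance that only a limit is reported again.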

Compound 4, half-maximal inhibitory concentration: > 100000 nM
Compound 4: a limit, no number; the forecaster's own chance of this, stated with the estimate: 65%; the middle value sits exactly at the limit.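

No step among compound 1, compound 2 and compound 4 can be read, since all three share one limit of the assay: the limit of > 100000 nM in this assay, at which 3 of the 4 values shown sit.

The compounds shown leave open how hydrogen, fluoro and methyl on the phenyl ring compare, and whether any difference would appear with the chain of compound 3.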